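A few compounds are considered here, and "the series" means these few. Any claim that something is new, unique, unknown or untested is made for them only; others in the source may bear on it.

In a functional assay for inhibition, with Homo sapiens as the target (on this read-out higher numbers stand for weaker inhibition and lower numbers for stronger inhibition), compound 3 `CCC1CS(=O)(=O)c2cc(C(=O)N=C(N)N)c(C)cc21` gives 78 nM. Compound 1 `Cc1cc2c(cc1C(=O)N=C(N)N)S(=O)(=O)CC2C(C)C` gives 77 nM and compound 2 `Cc1cc2c(cc1C(=O)N=C(N)N)S(=O)(=O)CC2(C)O` gives 115 nM. Compound 3 lies within the scatter of both, so it does not stand apart from either of them.

Compound 4 `Cc1cc2c(cc1C(=O)N=C(N)N)S(=O)(=O)CC2C` has not yet been measured. It differs from compound 3 by a single change, hydrogen in place of methyl on a saturated chain carbon bound to a saturated ring carbon: ethyl becomes methyl, with hydrogen in place of methyl on a saturated chain carbon bound to a saturated ring carbon.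

Within the data shown here, one measured step bears on this change: a 1.0-fold higher number from compound 1 to compound 3 (0.01 log units; within the scatter). It too puts hydrogen in place of methyl, though on a saturated chain carbon bound to a saturated chain carbon and a saturated ring carbon. Among the measured compounds shown here, it is only one comparison, at a different carbon, but it stays within the scatter. No shift beyond the scatter is therefore expected, and no direction can be named.

The expected step is small, a 1.0-fold higher number from compound 3 to compound 4 (0.01 log units; within the scatter). For compound 4 the estimated value is 80 nM, with an expected range from 40 nM to 160 nM.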

Compound 4, half-maximal inhibitory concentration: 182 nM
For compound 4 the middle estimate is 2.3-fold (0.36 log units) below the measured one; measured number outside the range, above it.
By their numbers in this assay, from the lowest: compounds 1, 3, 2 and 4 (each within the scatter of the next, the first and the last beyond it).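

In this assay, the group on this saturated ring carbon does count: ethyl to methyl gives a 2.3-fold higher number from compound 3 to compound 4 (0.37 log units; beyond the scatter) and isopropyl to methyl gives a 2.4-fold higher number from compound 1 to compound 4 (0.37 log units; beyond the scatter) beyond the scatter, whereas going from isopropyl to ethyl gave only a 1.0-fold higher number from compound 1 to compound 3 (0.01 log units; within the scatter) within it. The hydroxy compound behaves differently, since hydrogen in place of hydroxy gives a 1.6-fold higher number from compound 2 to compound 4 (0.20 log units; within the scatter) and so leaves compound 2 and compound 4 within the scatter of each other. Nothing available here explains why losing this one methyl has an effect when the earlier change had none.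

On these data alone, whether a longer chain such as propyl would stay with ethyl and isopropyl remains open. So does the effect of an amine or a carboxylic acid on this carbon.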